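Working notes: two limit values and a third analogue

The compounds below may be only part of what the source reports. "The series", "measured", "known", "first", "only" and "open" are said of these compounds alone.

Measured compounds:
compound 1 `COc1ccccc1-n1nncc1CN1C(=O)C2(C(C#N)=C(N)Oc3c2c2nc4ccccc4nc2c2ccccc32)c2ccccc21`: > 50000 nM
compound 2 `Cc1ccccc1-n1nncc1CN1C(=O)C2(C(C#N)=C(N)Oc3c(N)cc4nc5ccccc5nc4c32)c2ccccc21`: > 50000 nM

In a functional assay on HepG2 cells (Homo sapiens) for antiproliferative activity, read by MTT assay, with a stated time of 48 h (on this read-out higher numbers stand for weaker inhibition and lower numbers for stronger inhibition), compound 1 gives only a limit, > 50000 nM, not a number. Compound 2 likewise returns only a limit, > 50000 nM, so no numerical value places it within the series. Both measured values sit at the same limit, (the limit of > 50000 nM in this assay, at which 2 of the 2 values shown sit), and no step between measured compounds can be computed, so no direction of change has been shown so far.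

Compound 3 `CC(=O)Nc1ccc(-n2nncc2CN2C(=O)C3(C(C#N)=C(N)Oc4c(N)cc5nc6ccccc6nc5c43)c3ccccc32)cc1` differs from compound 2 by 4-acetamidophenyl in place of 2-methylphenyl on an aromatic nitrogen. Among the compounds with values here, the data hold no measured step on which to base a direction for this change. The step that the limit leaves unreadable from compound 2 to compound 3 is expected to stay within the scatter, with no clear direction beyond it. Compound 3 is estimated at 60000 nM, with a range from 10000 nM to 200000 nM, and a further limit value is the likelier outcome.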

Compound 3, half-maximal inhibitory concentration: > 50000 nM
Compound 3 ended at the assay's limit (the forecaster's own chance of this, stated with the estimate: 80%); the middle value does not contradict the limit.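

No step can be read from compound 2 to compound 3, because both values are limits and not numbers: the limit of > 50000 nM in this assay, at which 3 of the 3 values shown sit. The compounds shown leave open whether any change to the aromatic nitrogen substituent or the shared core gives a value off this limit.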